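Expected Cytotoxicity After Swapping Methyl for (Trifluoromethyl)sulfanyl

This account rests on a few compounds, and the source may have more. Where it says the series, first, only, none or still open, it means among the compounds named here.

Compound 1 `Cc1cc(NC(=O)Nc2ccc(C)c(Cl)c2)c2ccccc2n1` — > 25000 nM
Compound 2 `Cc1ccc(NC(=O)Nc2cc(C)nc3ccccc23)cc1` — > 25000 nM
Compound 3 `Cc1cc(NC(=O)Nc2cccc(C(N)=O)c2)c2ccccc2n1` — > 25000 nM

In an ADME assay on HepG2 cells (Homo sapiens) for cytotoxicity, with a stated time of 72 h (a lower number here means that less compound is needed, a higher number that more compound is needed for the effect), compound 1 gives > 25000 nM, a limit of the assay rather than a number. Compound 2 gives > 25000 nM, which is likewise a limit. Compound 3 gives > 25000 nM, again a limit. Compound 2 therefore stands at the limit of > 25000 nM in this assay, at which 3 of the 3 values shown sit, and no measured number places it more precisely. Among the measured compounds shown here, the single step between measured compounds, a step that the two limits leave unreadable from compound 1 to compound 2, cannot be read in size, so it gives no usable magnitude.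

Compound 4 `Cc1cc(NC(=O)Nc2ccc(SC(F)(F)F)cc2)c2ccccc2n1` differs from compound 2 by (trifluoromethyl)sulfanyl in place of methyl on an aromatic carbon. For the measured compounds named here, no measured step describes a change of this kind, and the one step in hand, a step that the two limits leave unreadable from compound 1 to compound 2, is unreadable. The expectation for compound 4 therefore rests only on the observation that all three measured compounds sit at the same limit (the limit of > 25000 nM in this assay, at which 3 of the 3 values shown sit).

Compound 4 is estimated at 30000 nM, with a range from 8000 nM to 100000 nM. The step that the limit leaves unreadable from compound 2 to compound 4 is expected to be none beyond the scatter, with a good chance that the assay again reports only a limit.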

Compound 4, half-maximal effective concentration: 20000 nM
Compound 4: middle estimate off by 1.5-fold (0.18 log units), on the high side; the measured number falls inside the stated range.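

In this assay compound 2 gives > 25000 nM, which is a limit of the assay and not a number. With (trifluoromethyl)sulfanyl in place of methyl on the aromatic carbon para to a large group, compound 4 gives a real number, 20000 nM. This position now carries a step with a stated floor, an at least 1.2-fold lower number from compound 2 to compound 4 (0.09 log units; that floor lies within the scatter), and that floor stays within the scatter, so the change cannot yet be told apart from the scatter of repeated measurements. Compound 4 is thus the only compound shown that gives a number rather than the value the others share: the limit of > 25000 nM in this assay, at which 3 of the 4 values shown sit.

From the compounds shown here alone, whether an amine or a carboxylic acid on the same aromatic carbon would also yield a number, and whether the sulfur or the fluorine atoms of the entering group matter for it, stays open. The step from compound 1 to compound 2 cannot be read, and a single number among the compounds shown gives no trend at this position.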